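A few compounds are considered here, and "the series" means these few. Any claim that something is new, unique, unknown or untested is made for them only; others in the source may bear on it.

Measured so far:
- compound 1, `N#Cc1c(N)nc(SCc2ccn[nH]2)c(C#N)c1-c1ccc(OCC2CC2)cc1`: 84 nM
- compound 2, `CCOc1ccc(-c2c(C#N)c(N)nc(SCc3ncc[nH]3)c2C#N)cc1`: 11.7 nM

Both were tested in a functional assay on CHO cells for agonist activity at adenosine receptor A2b (Homo sapiens), read by AlphaScreen and cAMP accumulation; a lower number here means that less compound is needed, a higher number that more compound is needed for the effect. Of the two numbers, compound 1 holds the higher one; compound 2 gives the lower number, and the gap between them lies beyond the usual scatter. Within the data shown here, no pair in the set differs in a single place, so no step can be read off directly.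

Compound 3, `CNC(=O)CSc1nc(N)c(C#N)c(-c2ccc(OCC3CC3)cc2)c1C#N`, is not yet measured. It derives from compound 1 by a single exchange on the sulfur-bound side chain: methylcarbamoyl in place of 1H-pyrazol-5-yl on a saturated chain carbon bound to a sulfur. The ring on that chain is given up for an open-chain amide of similar size, with one donor and one acceptor kept on each side.

Nothing in the set shows how this assay responds to such a change on the sulfur-bound chain. The expectation is therefore a modest step, most likely none beyond the scatter, with a slight lean toward a higher number; the step from compound 1 to compound 3 is estimated at a 1.3-fold higher number from compound 1 to compound 3 (0.12 log units; within the scatter). Compound 3 is expected to give about 110 nM, within a range of 30 nM to 400 nM.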

Compound 3, half-maximal effective concentration: 94 nM
The estimate for compound 3 lay 1.2-fold (0.07 log units) above the measured number, and the stated range covers the measured number.
By their numbers in this assay, from the lowest: compound 2; then compounds 1 and 3 (each within the scatter of the next).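

In this assay, among these compounds, the exchange of 1H-pyrazol-5-yl for methylcarbamoyl on a saturated chain carbon bound to a sulfur gives a 1.1-fold higher number from compound 1 to compound 3 (0.05 log units; within the scatter), the first step that can be read at a single place. On the core of compound 1, this position therefore accepts an open-chain methylcarbamoyl group with no ring in place of a five-membered aromatic ring without a change beyond the scatter, so that ring is not needed to keep the number at this level. The data at hand offer no explanation for this match between the two side chains.

This single pair does not show whether the position would accept equally a carboxylic acid, a primary amine or a longer chain such as (methylcarbamoyl)ethyl, so the limits of the tolerance remain undefined. Among the compounds shown here, compound 2 differs from compound 1 and compound 3 in more than one place, so no step to it can be read, and the effect of the ether group on the aryl ring and of the ring on the sulfur-bound chain cannot be separated.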